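This account rests on a few compounds, and the source may have more. Where it says the series, first, only, none or still open, it means among the compounds named here.

In a functional assay on CAL-51 cells (Homo sapiens) for inhibition, read by sulforhodamine B assay, with a stated time of 3 days (a lower number here means a stronger inhibitor of growth, a higher number a weaker inhibitor of growth), compound 1 `O=C(/C=C/c1ccccc1)c1ccc(OCc2ccccc2)cc1` gives 28900 nM. Compound 2 `O=C(/C=C/c1ccc(F)cc1)c1ccc(OCc2ccccc2)cc1` gives > 50000 nM, and this is a limit of the assay, not a number. Its exact place on the scale is therefore unknown.

Compound 3 `COc1cccc(/C=C/C(=O)c2ccc(OCc3ccccc3)cc2)c1` keeps the shared core and changes one group: 3-methoxyphenyl in place of 4-fluorophenyl on a double-bonded chain carbon bound to a double-bonded chain carbon. Here 3-methoxyphenyl replaces 4-fluorophenyl on a double-bonded chain carbon bound to a double-bonded chain carbon.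

Among the compounds with values here, only one measured step bears on this change, and only loosely. Fluoro in place of hydrogen on an aromatic carbon created the 4-fluorophenyl group that now leaves, giving an at least 1.7-fold higher number from compound 1 to compound 2 (0.23 log units; that floor lies within the scatter). Within the data shown here, that size is only a floor, and no measured step involves a methoxy group.

Compound 3 is thus expected to resemble compound 1 at 28900 nM, which lacks the fluoro group. The assay may still report only a limit for compound 3. The estimate is a small move toward a lower number, an at least 1.6-fold lower number from compound 2 to compound 3 (0.22 log units; that floor lies within the scatter), not clearly beyond the scatter. For compound 3 the expected value is 30000 nM, with an estimated range from 12000 nM to 50000 nM.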

Compound 3, concentration for 50% growth inhibition: 13700 nM
Estimate against measurement, compound 3: 2.2-fold (0.34 log units) above, and the stated range covers the measured number.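

Within the data shown here, with 3-methoxyphenyl on a double-bonded chain carbon bound to a double-bonded chain carbon, this position shows for the first time a change whose size can be read as a real difference in this assay: adding the methoxy group to the unsubstituted phenyl ring of compound 1 gives a 2.1-fold lower number from compound 1 to compound 3 (0.32 log units; beyond the scatter). Exchanging 4-fluorophenyl for 3-methoxyphenyl gives an at least 3.6-fold lower number from compound 2 to compound 3 (0.56 log units; beyond the scatter), so the two substituted rings are now clearly separated, which the earlier comparison of fluoro with hydrogen could not show. That size is only a floor, because compound 2 has a limit of the assay and not a number: the limit of > 50000 nM in this assay, at which 1 of the 3 values shown sits.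

The compounds shown leave open whether this gain is particular to the methoxy group or would also appear with another group at this place, such as an amine, a hydroxyl or a carboxylic acid. From the compounds shown here alone, the true value of compound 2 also remains unknown, so the full size of any step involving it cannot be read.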